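The source may report more compounds than this note shows. Statements on the series, on what has been measured and on what is new or still open speak of the compounds shown alone.

Three compounds sharing the same core have been examined in an ADME assay on HepG2 cells (Homo sapiens) for cytotoxicity, read by MTT assay, with a stated time of 24 h; on this read-out lower numbers stand for higher toxicity in this test and higher numbers for lower toxicity in this test. Compound 1 `CCc1ccc(C(=O)OCCCc2cn(-c3ccnc4cc(Cl)ccc34)nn2)cc1` gives > 2550000 nM there, a value that is a limit of the assay rather than a number. Compound 2 `CCc1ccccc1C(=O)OCc1cn(-c2ccnc3cc(Cl)ccc23)nn1` likewise gives > 2550000 nM in this assay, again a limit. Compound 3 `O=C(OCc1cn(-c2ccnc3cc(Cl)ccc23)nn1)c1ccccc1` gives > 2740000 nM in this assay, also a limit. For the measured compounds named here, the only single-point step among the measured compounds, a step that the two limits leave unreadable from compound 2 to compound 3, cannot be read, since both of its ends are limits. Compound 3 thus stands at one of the limits, with the two other values shown being limits as well; the whole picture is summed up by the limit of > 2550000 nM in this assay, at which 2 of the 3 values shown sit, and (the limit of > 2740000 nM in this assay, at which 1 of the 3 values shown sits).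

Compound 4 `COc1ccc(C(=O)OCc2cn(-c3ccnc4cc(Cl)ccc34)nn2)cc1` has yet to be measured in this assay. It differs from compound 3 by methoxy in place of hydrogen on an aromatic carbon. Going by the values given here, no measured step shows what a methoxy in place of hydrogen does here, and the one step between measured compounds, a step that the two limits leave unreadable from compound 2 to compound 3, is itself unreadable, so no size can be taken from it. Because every value in the limit of > 2550000 nM in this assay, at which 2 of the 3 values shown sit, and the limit of > 2740000 nM in this assay, at which 1 of the 3 values shown sits, sits at a limit, the step that the limit leaves unreadable from compound 3 to compound 4 is expected to be none beyond the scatter. Compound 4 is accordingly estimated at 3000000 nM, with a range from 1000000 nM to 10000000 nM, and is most likely to be reported again only as a limit.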

Compound 4, half-maximal cytotoxic concentration: 303000 nM
Compound 4: middle estimate off by 9.9-fold (1.00 log units), on the high side; the measured number lies below the stated range.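

In this assay, for the compounds shown here, putting methoxy in place of hydrogen on an aromatic carbon, para to a large group, gives the first step in this set that can be read: an at least 9.0-fold lower number from compound 3 to compound 4 (0.95 log units; beyond the scatter). Going by these compounds alone, exchanging 2-ethylphenyl for 4-methoxyphenyl on the carbonyl carbon likewise gives an at least 8.4-fold lower number from compound 2 to compound 4 (0.92 log units; beyond the scatter), so compound 4 is the one compound here that stands apart from the others with a number rather than a limit, and both steps give only the least size of the change. The step from compound 2 to compound 3 still cannot be read, and the earlier compounds alone gave no number to work from: the limit of > 2550000 nM in this assay, at which 2 of the 4 values shown sit.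

The full size of both new steps stays open, since the values at their starting ends are limits, and nothing shown tells why methoxy at this place lowers the number. As far as these compounds go, it also remains open whether a hydroxyl, an amine or a chlorine at the same place would lower the number in this assay as methoxy does, and whether methoxy would do so with the longer chain that compound 1 carries.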